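The compounds below may be only part of what the source reports. "The series", "measured", "known", "first", "only" and "open" are said of these compounds alone.

Compound 1 `CCCSc1nc(N/N=C/c2cccnc2)c2nnn(Cc3ccccc3)c2n1`: 58700 nM
Compound 2 `CCCSc1nc(N/N=C(\C)c2ccc(O)cc2)c2nnn(Cc3ccccc3)c2n1`: 21600 nM
Compound 3 `CCCSc1nc(N/N=C(\C)c2ccc(OC)cc2)c2nnn(Cc3ccccc3)c2n1`: > 64000 nM (a limit of the assay, not a number)

These three compounds share one core and were tested in a functional assay on MCF7 cells (Homo sapiens) for antiproliferative activity, read by MTT assay, with a stated time of 72 h; a higher number here means a weaker inhibitor, a lower number a stronger inhibitor. Compound 2 has the lower of the two actual numbers, and its steps to both neighbours lie beyond the scatter, so it is the strongest of the three here. Compound 3 gave only a limit, (the limit of > 64000 nM in this assay, at which 1 of the 3 values shown sits).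

The next compound is compound 4 `CCCSc1nc(N/N=C/c2cccc(Cl)c2)c2nnn(Cc3ccccc3)c2n1`, which has not yet been measured. Its difference from compound 2 is a group of 9 heavy atoms (7 carbon, 1 nitrogen, 1 chlorine; one six-membered aromatic ring of carbon only) in place of a group of 10 heavy atoms (8 carbon, 1 nitrogen, 1 oxygen; one six-membered aromatic ring of carbon only), on a nitrogen on an aromatic ring: a group of 9 heavy atoms in place of a group of 10 heavy atoms, on a nitrogen on an aromatic ring.

Among the measured compounds shown here, two measured steps bear on this change. Exchanging the group at that same place gave a 2.7-fold lower number from compound 1 to compound 2 (0.43 log units; beyond the scatter). Changing only the group on the oxygen gave an at least 2.9-fold higher number from compound 2 to compound 3 (0.47 log units; beyond the scatter), and that oxygen leaves altogether in compound 4. Both steps are small, and in both the group of compound 2 gave the lower number, so any shift is expected toward a higher number. The expected outcome is no step beyond the scatter: a 1.5-fold higher number from compound 2 to compound 4 (0.17 log units; within the scatter). For compound 4 the estimate is 32000 nM, with an expected range from 13000 nM to 64000 nM.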

Compound 4, half-maximal inhibitory concentration: > 64000 nM
Compound 4 gave a limit, no number; the forecaster's own chance of this, stated with the estimate: 20%; middle value at least 2.0-fold (0.30 log units) from the limit.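

Compound 4 gave > 64000 nM, a limit and not a number: the limit of > 64000 nM in this assay, at which 2 of the 4 values shown sit.

Even with that limit the step can be read: exchanging the group on the nitrogen gave an at least 2.9-fold higher number from compound 2 to compound 4 (0.47 log units; beyond the scatter), so the lower number of compound 2 does not carry over to this other ring-bearing group. Together with an at least 2.9-fold higher number from compound 2 to compound 3 (0.47 log units; beyond the scatter), this means that compound 2, the only one of these three with a free hydroxyl, keeps the lower number both when that hydroxyl is capped with methyl and when the oxygen is gone, though the exchange to compound 4 alters more than the oxygen. The other step, an at least 1.0-fold higher number from compound 1 to compound 4 (0.03 log units; that floor lies within the scatter), has a floor within the scatter, so 3-chlorophenyl and pyridin-3-yl cannot be put in order at this place.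

Still open, from the compounds shown here alone, is whether the hydroxyl or the methyl on the carbon with a double bond to nitrogen, present in compound 2 and absent from compound 4, accounts for the step. Going by these compounds, it is also open how an amine or a carboxylic acid would read in place of that hydroxyl.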